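Aryl Swap on a Triazole Nitrogen: Compound 4 Awaited

The source may hold more compounds than are shown below. What is called first, only, known or untested is meant among the compounds shown, and "the series" means these compounds.

Three spirocyclic compounds sharing one core have been tested for antiproliferative activity in a functional assay on A549 cells (Homo sapiens) for antiproliferative activity, read by MTT assay, with a stated time of 48 h; a lower number here means a stronger inhibitor, a higher number a weaker inhibitor. Compound 1 `N#CC1=C(N)Oc2c(c3nc4ccccc4nc3c3ccccc23)C12C(=O)N(Cc1cnnn1-c1cccc(S(N)(=O)=O)c1)c1ccccc12` gives 44200 nM in this assay. Compound 2 `CC(=O)Nc1ccc(-n2nncc2CN2C(=O)C3(C(C#N)=C(N)Oc4c(N)cc5nc6ccccc6nc5c43)c3ccccc32)cc1` gives > 50000 nM in this assay, which is a limit of the assay and not a number. Compound 3 `CCOc1ccccc1-n1nncc1CN1C(=O)C2(C(C#N)=C(N)Oc3c(N)cc4nc5ccccc5nc4c32)c2ccccc21` gives > 50000 nM in this assay, again a limit and not a number. Among the compounds with values here, compound 3 therefore stands only at a limit, and the single step that leads to it, a step that the two limits leave unreadable from compound 2 to compound 3, cannot be read in size or direction, since both ends are limits. Within the data shown here, the only evidence bearing on compound 3 is the limit of > 50000 nM in this assay, at which 2 of the 3 values shown sit.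

Compound 4 `Cc1ccc(Cl)cc1-n1nncc1CN1C(=O)C2(C(C#N)=C(N)Oc3c(N)cc4nc5ccccc5nc4c32)c2ccccc21` differs from compound 3 in one place: 5-chloro-2-methylphenyl in place of 2-ethoxyphenyl on an aromatic nitrogen. No measured step concerns an aryl exchange on that aromatic nitrogen with a readable size, so nothing shown suggests a change beyond the scatter in this assay. Given that compound 3 sits at the limit > 50000 nM, compound 4 is expected to remain near that limit as well, with the step that the limit leaves unreadable from compound 3 to compound 4 expected to be small. The estimate for compound 4 in this assay is 60000 nM, within a range from 20000 nM to 200000 nM.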

Compound 4, half-maximal inhibitory concentration: > 50000 nM
Compound 4: no number, only a limit (the forecaster's own chance of this, stated with the estimate: 75%); the middle value is on the limit's open side.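

In this assay compound 4 gives > 50000 nM, a limit of the assay and not a number. No new step can be read: compound 4 compared with compound 2 or compound 3 has limits at both ends. The compounds shown leave open whether exchanging these aryl groups on the aromatic nitrogen changes activity at all: the limit of > 50000 nM in this assay, at which 3 of the 4 values shown sit.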